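Swapping the phenyl group of compound 1 and its solubility

The source may hold more compounds than are shown below. What is called first, only, known or untested is meant among the compounds shown, and "the series" means these compounds.

Compound 1 `Cc1oc(-c2c(Cl)cccc2Cl)nc1CN1CCC(C(=O)NCCCN2C[C@H](C)C[C@H](C)C2)CC1` was examined in a physicochemical assay for solubility, in phosphate buffer, measured as kinetic solubility, at pH 7.4; on this read-out higher numbers stand for higher solubility and lower numbers for lower solubility. In this assay compound 1 gives > 77 ug/mL, which is a limit of the measurement rather than a number. Two related compounds were tested alongside it. Compound 2 `Cc1ccccc1-c1nc(CN2CCC(C(=O)NCCN3C[C@H](C)C[C@H](C)C3)CC2)c(C)o1` likewise gives only a limit, > 67 ug/mL. Compound 3 `Cc1ccccc1-c1nc(CN2CCC(C(=O)N3CCN(C4CCN(C)CC4)CC3)CC2)c(C)o1` also gives a limit, > 71 ug/mL. Within the data shown here, all three values therefore sit at limits, as set out in the limit of > 67 ug/mL in this assay, at which 1 of the 3 values shown sits, the limit of > 71 ug/mL in this assay, at which 1 of the 3 values shown sits, and (the limit of > 77 ug/mL in this assay, at which 1 of the 3 values shown sits), and none of them can be placed above or below another; compound 1 stands at a limit like the others, and no step between measured compounds can be computed.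

The next compound, compound 4 `Cc1ccc(-c2nc(CN3CCC(C(=O)NCCCN4C[C@H](C)C[C@H](C)C4)CC3)c(C)o2)c(C)c1`, has not yet been measured. It differs from compound 1 in one place: 2,4-dimethylphenyl in place of 2,6-dichlorophenyl on an aromatic carbon. Since every measured value is a limit, the data give no step on which to lean, and no reason can be offered for what the change does.

On that basis compound 4 is expected to behave much like compound 1, with a step that the limit leaves unreadable from compound 1 to compound 4, that is no change beyond the scatter and most likely another limit. The estimate for compound 4 in this assay is 80 ug/mL, within a range from 40 ug/mL to 160 ug/mL.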

Compound 4, solubility: > 71 ug/mL
Compound 4: a limit, no number; the forecaster's own chance of this, stated with the estimate: 75%; the middle value lies beyond the limit too.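

In this assay compound 4 gives > 71 ug/mL, which is a limit of the measurement and not a number. Among these compounds, compound 1 also stands at a limit, so no step between compound 1 and compound 4 can be read. The compounds shown leave open where any of the actual values lies, and whether 2,4-dimethylphenyl in place of 2,6-dichlorophenyl changes the read-out at all.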